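Taking the methoxy group off a very long-lasting compound

This account rests on a few compounds, and the source may have more. Where it says the series, first, only, none or still open, it means among the compounds named here.

In a physicochemical assay for pharmacokinetics (a lower number here means that the compound disappears faster, a higher number that the compound lasts longer), compound 1 `COc1cccc(CNC(=O)N2C(=O)c3ccccc3S2(=O)=O)c1` gives > 166 h as a limit of the assay and not as an exact number. Compound 2 `O=C(c1ccccc1)N1C(=O)c2ccccc2S1(=O)=O` gives > 166 h in this assay and this too is only a limit.

Compound 3 `O=C(NCc1ccccc1)N1C(=O)c2ccccc2S1(=O)=O` has hydrogen in place of methoxy on an aromatic carbon so 3-methoxyphenyl becomes phenyl. For the measured compounds named here, no measured pair of compounds shows this change on its own, so there is no direct guide to its size. The expected step that the limit leaves unreadable from compound 1 to compound 3 stays within the usual scatter of this assay and has no clear direction. This expectation rests on compound 1 and its > 166 h result, which is a limit. For compound 3 the estimated half-life is 200 h with an expected range from 120 h to 400 h and the result may again be only a limit.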

Compound 3, half-life: > 166 h
Compound 3 was reported as a limit; the forecaster's own chance of this, stated with the estimate: 85%; the middle value does not contradict the limit.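

No step can be read between compound 1 and compound 3, because neither result is an exact number: the limit of > 166 h in this assay, at which 3 of the 3 values shown sit.

The compounds shown leave open how long each one really lasts in this assay, and so whether going from 3-methoxyphenyl to phenyl changes the half-life at all.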